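Swapping a Hydroxyphenyl for a Methoxyphenyl

This account rests on a few compounds, and the source may have more. Where it says the series, first, only, none or still open, it means among the compounds named here.

Compound 1 `O=C1N=C(N2N=C(c3ccccc3)CC2c2ccccc2O)S/C1=C1/C(=O)Nc2ccccc21` gives 4730 nM in a functional assay on cells (Cancer cell lines, Homo sapiens) for cytotoxicity, read by sulforhodamine B assay, with a stated time of 48 h; on this read-out lower numbers stand for stronger inhibition of growth and higher numbers for weaker inhibition of growth.
Compound 2 `O=C1N=C(N2N=C(c3ccccc3)CC2c2ccccc2O)S/C1=C1/C(=O)Nc2ccc(Br)cc21` gives 670 nM in this assay.

Compound 1 stands highest of the two numbers; its nearest neighbour is compound 2, reached by a 7.1-fold lower number from compound 1 to compound 2 (0.85 log units; beyond the scatter). Compound 3 `COc1ccc(C2CC(c3ccccc3)=NN2C2=NC(=O)/C(=C3\C(=O)Nc4ccccc43)S2)cc1` differs from compound 1 elsewhere: 4-methoxyphenyl in place of 2-hydroxyphenyl on a saturated ring carbon. Among the measured compounds shown here, no measured step touches this position, so there is no guide for direction or size, and the expectation is a step within the usual scatter. Compound 3 is therefore estimated at 5000 nM, between 1500 nM and 16000 nM, meaning a 1.1-fold higher number from compound 1 to compound 3 (0.02 log units; within the scatter).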

Compound 3, concentration for total growth inhibition: 6040 nM
Compound 3: middle estimate off by 1.2-fold (0.08 log units), on the low side; the range from low to high includes it.
By their numbers in this assay, from the lowest: compound 2; then compounds 1 and 3 (each within the scatter of the next).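

In this assay putting 4-methoxyphenyl in place of 2-hydroxyphenyl on a saturated ring carbon gives a 1.3-fold higher number from compound 1 to compound 3 (0.11 log units; within the scatter) and stays within the scatter. This position therefore tolerates this swap, even though the count of hydrogen-bond donors in the group falls from 1 to 0. Nothing measured here explains this result. The compounds shown leave open whether an amine or a carboxylic acid on this phenyl ring would shift the number. They also leave open whether adding the bromo group of compound 2 would have the same effect on compound 3.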